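Furan-3-yl for Thiophen-2-yl: Cytotoxicity on Huh-7 Cells

The source may report more compounds than this note shows. Statements on the series, on what has been measured and on what is new or still open speak of the compounds shown alone.

Measured compounds:
compound 1 `C[C@@]1(O)[C@H](O)[C@@H](CO)O[C@H]1n1cc(-c2cccs2)c2c(N)ncnc21`: 48100 nM
compound 2 `C[C@@]1(O)[C@H](O)[C@@H](CO)O[C@H]1n1cc(-c2ccoc2)c2c(N)ncnc21`: > 44000 nM
compound 3 `Nc1ncnc2c1c(-c1cccs1)cn2[C@H]1C[C@H](O)[C@@H](CO)O1`: > 44000 nM

In a toxicity assay on Huh-7 cells (Homo sapiens) for cytotoxicity, with a stated time of 3 days (on this read-out lower numbers stand for higher toxicity in this test and higher numbers for lower toxicity in this test), compound 1 gives 48100 nM. For compound 2 the result is a limit of the test, > 44000 nM. For compound 3 the result is likewise a limit, > 44000 nM. The change from compound 1 to compound 2 is furan-3-yl in place of thiophen-2-yl on an aromatic carbon, and its step in this assay is a step that the limit leaves unreadable from compound 1 to compound 2. The difference between the core of compound 1 and that of compound 3 is not broken down here. Compound 4 `Nc1ncnc2c1c(-c1ccoc1)cn2[C@H]1C[C@H](O)[C@@H](CO)O1` arises from compound 3 by the same kind of change, (furan-3-yl in place of thiophen-2-yl on an aromatic carbon), the ring atom here bearing a group of 8 heavy atoms rather than a large group. Compound 4 is expected to follow compound 3 and reach the limit, because compound 3 already sits at the limit of > 44000 nM in this assay, at which 2 of the 3 values shown sit. Compound 4 is thus estimated at 50000 nM in this assay, a step that the limit leaves unreadable from compound 3 to compound 4.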

Compound 4, half-maximal cytotoxic concentration: > 44000 nM
Compound 4 was reported as a limit (the forecaster's own chance of this, stated with the estimate: 85%); the middle value does not contradict the limit.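

The results for compound 3 and compound 4 in this assay are both limits, and no step can be read between them. The compounds shown leave open whether furan-3-yl in place of thiophen-2-yl changes the read-out on either core.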